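A longer chain against the cytotoxicity limit

This account rests on a few compounds, and the source may have more. Where it says the series, first, only, none or still open, it means among the compounds named here.

Compound 2 `CCCCNc1cncc(C(=O)NCc2ccccc2)n1` was tested in an ADME assay on HeLa cells (Homo sapiens) for cytotoxicity, read by microscopy, with a stated time of 6 days (on this read-out higher numbers stand for lower toxicity in this test and lower numbers for higher toxicity in this test), where it gives > 100000 nM, a limit of the test rather than a number. Compound 1 `CCCCCCCNc1cnc(C(=O)NCc2ccccc2)cn1` gives > 100000 nM, also a limit. Compound 3 `CCCCCCCNc1nccnc1C(=O)NCc1ccccc1` likewise gives > 100000 nM, a limit. Compound 2 thus stands where every other value shown stands: the limit of > 100000 nM in this assay, at which 3 of the 3 values shown sit. Compound 4 `CCCCCNc1cncc(C(=O)NCc2ccccc2)n1` has not yet been measured in this assay. It differs from compound 2 by methyl in place of hydrogen on a saturated chain carbon, four bonds along the chain from a nitrogen on an aromatic ring. For the measured compounds named here, with all three values sitting at the limit and no measured step between any two compounds, the data give no direction for this change. The step of a number no higher from compound 2 to compound 4 (the limit leaves the size open) is therefore expected to be none beyond the scatter. Compound 4 is expected to give 100000 nM, within a range from 50000 nM to 200000 nM.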

Compound 4, minimum cytotoxic concentration: > 100000 nM
Compound 4: only a limit was reported; the forecaster's own chance of this, stated with the estimate: 85%; the middle value sits exactly at the limit.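

For the compounds shown here, compound 2 and compound 4 both sit at the limit of the test, so no step between them can be read. The compounds shown leave open at what concentration, if any, any of them harms these cells.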